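The compounds below may be only part of what the source reports. "The series", "measured", "known", "first", "only" and "open" are said of these compounds alone.

Three compounds of one series were tested in an ADME assay on HEK-293T cells (Homo sapiens) for cytotoxicity, read by luminescence and CellTiter-Glo, with a stated time of 24 h; on this read-out higher numbers stand for weaker inhibition and lower numbers for stronger inhibition. Compound 1 `C=C1C[C@]23C[C@@]1(O)CC[C@H]2c1ccc(O/C=C/C(=O)OC)c(C)c1[C@@H]3C(=O)OC` reaches only the limit of this assay, giving > 10000 nM. Compound 2 `C=C1C[C@]23C[C@@]1(O)CC[C@H]2[C@@]12C=C[C@H](O)[C@@](C)(C(=O)O1)[C@H]2[C@@H]3C(=O)OC` likewise stops at the limit, giving > 10000 nM. Compound 3 `C=C1C[C@]23C[C@@]1(O)CC[C@H]2c1cc2c(C(=O)OC)coc2c(C)c1[C@@H]3C(=O)OC` also returns the limit, giving > 10000 nM. Compound 2 thus stands where every measured value in this series stands, at the limit of > 10000 nM in this assay, at which 3 of the 3 values shown sit, so no number separates it from the others. Compound 4 `C=C1[C@@H](O)[C@]23C[C@@]1(O)CC[C@H]2[C@@]12C=C[C@H](O)[C@@](C)(C(=O)O1)[C@H]2[C@@H]3C(=O)OC` comes from compound 2 by hydroxy in place of hydrogen on a saturated ring carbon. Within the data shown here, no measured pair differs by this change alone, so the expected step from compound 2 to compound 4 in this assay is a step that the limit leaves unreadable from compound 2 to compound 4, which means nothing beyond the scatter. Compound 4 is therefore estimated at 20000 nM, with an expected range from 8000 nM to 100000 nM.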

Compound 4, half-maximal inhibitory concentration: > 10000 nM
Compound 4 ended at the assay's limit; the forecaster's own chance of this, stated with the estimate: 85%; the middle value does not contradict the limit.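

No step can be read from compound 2 to compound 4, because both sit at a limit rather than at a number: the limit of > 10000 nM in this assay, at which 4 of the 4 values shown sit. The compounds shown leave open whether hydroxy in place of hydrogen changes anything in this assay, and how strongly any of these compounds would inhibit there.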